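Solubility of a Bulkier Amide Cap on the Shared Core

A few compounds are considered here, and "the series" means these few. Any claim that something is new, unique, unknown or untested is made for them only; others in the source may bear on it.

Of the compounds shown here, three sharing one core have been measured in a physicochemical assay for solubility, read by HPLC; on this read-out lower numbers stand for lower solubility and higher numbers for higher solubility. Compound 1 `CCC(=O)N1CCN(c2nc(=O)c3cc(C(F)(F)F)cc([N+](=O)[O-])c3s2)CC1` gives 3.29 ug/mL, compound 2 `O=C(C1CCCCC1)N1CCN(c2nc(=O)c3cc(C(F)(F)F)cc([N+](=O)[O-])c3s2)CC1` gives 3.24 ug/mL, and compound 3 `O=C(C1CCCC1)N1CCN(c2nc(=O)c3cc(C(F)(F)F)cc([N+](=O)[O-])c3s2)CC1` gives 5.34 ug/mL. Compound 3 carries the highest number of the three, yet both gaps to it, a 1.6-fold higher number from compound 1 to compound 3 (0.21 log units; within the scatter) and a 1.6-fold higher number from compound 2 to compound 3 (0.22 log units; within the scatter), sit within the scatter, so the three values cannot be told apart.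

Compound 4 `CC(C)(C)C1CCC(C(=O)N2CCN(c3nc(=O)c4cc(C(F)(F)F)cc([N+](=O)[O-])c4s3)CC2)CC1` is the next step from compound 3. The change is 4-(tert-butyl)cyclohexyl in place of cyclopentyl on a carbonyl carbon. For the measured compounds named here, the nearest precedent is the step of a 1.0-fold lower number from compound 1 to compound 2 (0.01 log units; within the scatter), where a larger ring in place of a small chain left this assay unchanged, and the ring-size step a 1.6-fold higher number from compound 2 to compound 3 (0.22 log units; within the scatter) was likewise flat. Going by the values given here, no measured compound carries a tert-butyl group, so that part of the change has no precedent here. Given how little the amide cap has moved this assay so far, the expected step of a 2.1-fold lower number from compound 3 to compound 4 (0.33 log units; beyond the scatter) is small, leaning toward a lower number. Compound 4 is therefore estimated at 2.5 ug/mL, with a range from 0.8 ug/mL to 6 ug/mL.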

Compound 4, solubility: < 0.1 ug/mL
Compound 4 was reported as a limit; the forecaster's own chance of this, stated with the estimate: 10%; middle value at least 25-fold (1.39 log units) from the limit.
By their numbers in this assay, from the lowest: compounds 2, 1 and 3 (each within the scatter of the next). At a limit, below all of these: compound 4.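

In this assay, compound 4 is reported only as a limit, < 0.1 ug/mL, and not as a number. Compound 1, compound 2 and compound 3 gave no sign that the group on this carbonyl carbon matters, but the new cap changes that: the result is an at least 53-fold lower number from compound 3 to compound 4 (1.72 log units; beyond the scatter), and the comparison with the first compound is similar, an at least 32-fold lower number from compound 1 to compound 4 (1.51 log units; beyond the scatter). For the compounds shown here, the clearest reading is an at least 32-fold lower number from compound 2 to compound 4 (1.51 log units; beyond the scatter), where the only change is tert-butyl in place of hydrogen on a saturated ring carbon, so that single added group goes with the whole drop.

From the compounds shown here alone, it remains open whether this drop is tied to tert-butyl itself or would follow any group at that ring carbon, such as a methyl, a hydroxyl or an amine. Going by these compounds, how far the true value of compound 4 lies past its limit also remains unknown.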